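The compounds below may be only part of what the source reports. "The series", "measured", "known", "first", "only" and "open" are said of these compounds alone.

Measured so far in an assay on isolated protein for agonist activity at Alpha-2B adrenergic receptor (Homo sapiens); on this read-out higher numbers stand for larger maximal responses and lower numbers for smaller maximal responses:
- compound 1 `CC(Oc1ccccc1OC1CC1)C1=NCCN1` gives 0.6
- compound 2 `CC(Oc1ccccc1Br)C1=NCCN1` gives 0.4

Within the data shown here, compound 2 stands at the lowest of the two numbers; its nearest neighbour is compound 1, and the one measured step, a number 0.20 lower from compound 1 to compound 2 (beyond the scatter), put bromo in place of cyclopropyloxy on an aromatic carbon. Compound 3 `CCCc1ccccc1OC(C)C1=NCCN1` is the next step from compound 2: propyl in place of bromo on an aromatic carbon. Among the measured compounds shown here, the only step that bears on it is a number 0.20 lower from compound 1 to compound 2 (beyond the scatter), which shows that removing bromo's neighbour group in favour of bromo lowered the response by a modest amount. For the measured compounds named here, there is no measured step that introduces propyl, so the direction of the change from bromo to propyl is open; at most a modest move is expected, and it may stay within the scatter. Compound 3 is therefore estimated at 0.5 in this assay, between 0.3 and 0.7, which means a step of a number 0.10 higher from compound 2 to compound 3 (within the scatter).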

Compound 3, intrinsic activity: the largest response reached, as a fraction of the reference agonist's: 0.6
For compound 3 the middle estimate is 0.10 below the measured one; measured number inside the range.
By their numbers in this assay, from the lowest: compound 2; then compounds 1 and 3 (each within the scatter of the next).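

In this assay, the aromatic carbon that held bromo responds to a change of group in the upward direction as well: propyl in place of bromo gives a number 0.20 higher from compound 2 to compound 3 (beyond the scatter). Propyl in place of cyclopropyloxy gives no change at the digits printed from compound 1 to compound 3 (within the scatter), so these two groups cannot be told apart at this position, and of the three groups only bromo stands lower. Nothing measured here accounts for the difference between bromo and propyl.

As far as these compounds go, whether a longer chain such as butyl, or an amine or a hydroxyl on the same aromatic carbon, would hold the response or let it fall back towards that of compound 2 remains open. From the compounds shown here alone, it is also open whether any group at this position lifts the response beyond that of compound 3, at 0.6.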